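Changing the aryl group on a sulfonamide-linked amine

The compounds below may be only part of what the source reports. "The series", "measured", "known", "first", "only" and "open" are said of these compounds alone.

Going by the values given here, compound 2 `COc1ccc(CNCCCNS(=O)(=O)c2cc(C(F)(F)F)cc(C(F)(F)F)c2)cc1OC` is one of three compounds measured in a functional assay on MIA PaCa-2 cells (Homo sapiens) for inhibition, read by MTT assay, with a stated time of 72 h; on this read-out lower numbers stand for stronger inhibition of growth and higher numbers for weaker inhibition of growth. There compound 2 gives 2800 nM. Compound 1 `O=S(=O)(NCCCNCc1cccc2ccccc12)c1cc(C(F)(F)F)cc(C(F)(F)F)c1` gives 2800 nM in this assay, which is level with compound 2; together these two hold the lowest of the three numbers. Compound 3 `O=S(=O)(NCCCCCCNCc1ccc(Br)cc1)c1ccc2c(c1)OCC2`, built on a different core and a longer chain, gives 13000 nM in this assay, a higher number than compound 2 and beyond the scatter.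

Among the compounds with values here, the one measured step that changes a single place replaces naphthalen-1-yl with 3,4-dimethoxyphenyl on a saturated chain carbon bound to an amine nitrogen, and it gave no change at the digits printed from compound 1 to compound 2 (within the scatter).

Compound 4 `O=S(=O)(NCCCNCc1ccccc1Cl)c1cc(C(F)(F)F)cc(C(F)(F)F)c1` has not yet been measured. It differs from compound 2 in one place: 2-chlorophenyl in place of 3,4-dimethoxyphenyl on a saturated chain carbon bound to an amine nitrogen. Within the data shown here, the only measured step that bears on this change is the one from compound 1 to compound 2, where an aryl group at the same place was exchanged with no shift beyond the scatter. On that basis the expected step of no change at the digits printed from compound 2 to compound 4 (within the scatter) is none beyond the scatter in this assay. Compound 4 is therefore estimated at 2800 nM in this assay, with a range from 1200 nM to 6500 nM.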

Compound 4, concentration for 50% growth inhibition: 11000 nM
The estimate for compound 4 lay 3.9-fold (0.59 log units) below the measured number; measured number above the stated range.
By their numbers in this assay, from the lowest: compounds 1 and 2 (each within the scatter of the next); then compounds 4 and 3 (each within the scatter of the next).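

In this assay this position proves not to treat all aryl groups alike: putting 2-chlorophenyl in place of 3,4-dimethoxyphenyl gives a 3.9-fold higher number from compound 2 to compound 4 (0.59 log units; beyond the scatter) and putting it in place of naphthalen-1-yl gives a 3.9-fold higher number from compound 1 to compound 4 (0.59 log units; beyond the scatter) in this series. The earlier match between compound 1 and compound 2 therefore does not extend to every aryl group on a saturated chain carbon bound to an amine nitrogen, even though 2-chlorophenyl, like 3,4-dimethoxyphenyl, is one six-membered aromatic ring of carbon only. Nothing available here accounts for the higher number of compound 4.

The compounds shown do not separate the effect of gaining the chlorine from that of losing the two methoxy groups, and a plain phenyl group or a fluorophenyl group at this place would help to tell these apart. They also leave open whether these aryl groups would compare in the same way on a longer chain attached to the core of compound 2.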